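This account rests on a few compounds, and the source may have more. Where it says the series, first, only, none or still open, it means among the compounds named here.

Measured compounds:
compound 1, `COc1cc2nc(NCc3ccccc3)nc(NC3CCCCCC3)c2cc1OC` — < 0%
compound 2, `COc1cc2nc(NCCCN3CCCC3=O)nc(NC3CCCCCC3)c2cc1OC` — 8%

Among the measured compounds shown here, in an in vitro assay on B300-19 cells for displacement of a labelled ligand from C-C chemokine receptor type 4 (Homo sapiens), tested at 1 uM (on this read-out higher numbers stand for more inhibition at the one concentration tested (going by the name of the read-out) and lower numbers for less inhibition), compound 2 gives 8%, the only plain number among the two values shown. Compound 1 gives only a limit of the assay, < 0%; the limit of < 0% in this assay, at which 1 of the 2 values shown sits, notes this. For the measured compounds named here, the one measured step, a number at least 8 percentage points higher from compound 1 to compound 2 (that floor lies within the scatter), replaced a phenyl with 2-(2-oxopyrrolidin-1-yl)ethyl, and its floor lies within the usual scatter, so the step is not clearly beyond it.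

Compound 3, `COc1cc2nc(NCc3cccs3)nc(NC3CCCCCC3)c2cc1OC`, carries the change (thiophen-2-yl in place of 2-(2-oxopyrrolidin-1-yl)ethyl on a saturated chain carbon bound to a nitrogen on an aromatic ring). Going by the values given here, this is the only step that bears on it, read in the reverse sense: compound 3 again places a five-membered aromatic ring where compound 2 holds the 2-(2-oxopyrrolidin-1-yl)ethyl chain, much as compound 1 held a phenyl there. Since compound 1 sits at the limit, a small move downward, not beyond the scatter and possibly back to the limit, is expected. The estimated step is a number 6 percentage points lower from compound 2 to compound 3 (within the scatter). Compound 3 is therefore expected to give about 2% in this assay, within -10% to 12%.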

Compound 3, a percentage reported as inhibition, at one concentration (the size of the read-out at that concentration, not a potency): < 0%
Compound 3 ended at the assay's limit (the forecaster's own chance of this, stated with the estimate: 40%); at least 2 percentage points between middle value and limit.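

At this position, on a saturated chain carbon bound to a nitrogen on an aromatic ring, putting thiophen-2-yl in place of 2-(2-oxopyrrolidin-1-yl)ethyl gives a number at least 8 percentage points lower from compound 2 to compound 3 (that floor lies within the scatter), so this change, like the earlier one, is not clearly beyond the scatter. In this assay compound 3 gives < 0%, which is a limit of the assay and not a number. Thiophen-2-yl now stands with phenyl as a second aromatic ring at this position that ends at the limit, and the step between those two compounds cannot be read since the limit hides both of their true values: the limit of < 0% in this assay, at which 2 of the 3 values shown sit.

Going by these compounds, whether an amine at the end of a longer chain, or a carboxylic acid, would carry the read-out at this position clearly beyond the scatter stays open. All three compounds also share the same core and the same group on its other nitrogen, so the effect of a change anywhere else on the molecule is open too.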